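The compounds below may be only part of what the source reports. "The series", "measured", "known", "first", "only" and "open" are said of these compounds alone.

Working notes on the series. Compound 1 `c1ccc(C2=NN(c3ccc(-c4ccccc4)nn3)C(c3ccccc3)C2)cc1` is the reference; in a functional assay on HepG2 cells (Homo sapiens) for antiproliferative activity, read by MTT assay, with a stated time of 24 h (a lower number here means a stronger inhibitor, a higher number a weaker inhibitor), compound 1 gives 10000 nM. Compound 2 `Clc1ccc(C2CC(c3ccccc3)=NN2c2ccc(-c3ccccc3)nn2)cc1` differs from compound 1 by chloro in place of hydrogen on an aromatic carbon, and in this assay compound 2 gives 6310 nM; the step of a 1.6-fold lower number from compound 1 to compound 2 (0.20 log units; within the scatter).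

Compound 3 `COc1ccc(C2=NN(c3ccc(-c4ccccc4)nn3)C(c3ccccc3)C2)cc1` differs from compound 1 by methoxy in place of hydrogen on an aromatic carbon. In this assay compound 3 reaches only a limit of the assay, > 100000 nM. The step of an at least 10-fold higher number from compound 1 to compound 3 (1.00 log units; beyond the scatter) rests on (the limit of > 100000 nM in this assay, at which 1 of the 3 values shown sits), so its true size is not fixed.

Compound 4 `COc1ccc(C2=NN(c3ccc(-c4ccccc4)nn3)C(c3ccc(Cl)cc3)C2)cc1` is not yet measured. It carries the same change relative to compound 3 as compound 2 carries relative to compound 1: chloro in place of hydrogen on an aromatic carbon. The two places read identically, so this is the same change, seen twice in all among the compounds shown. The measured instance, a 1.6-fold lower number from compound 1 to compound 2 (0.20 log units; within the scatter), lay within the scatter, and the step from compound 3 to compound 4 is expected to be of similar size, a number no higher from compound 3 to compound 4 (the limit leaves the size open), starting from a limit. Compound 4 is therefore estimated at 100000 nM in this assay, expected to fall between 30000 nM and 400000 nM, with a real chance that only a limit is reported.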

Compound 4, half-maximal inhibitory concentration: > 100000 nM
Compound 4 ended at the assay's limit (the forecaster's own chance of this, stated with the estimate: 55%); the middle value lies on the limit itself.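

In this assay, methoxy in place of hydrogen on an aromatic carbon, carried onto the core of compound 2, gives an at least 15-fold higher number from compound 2 to compound 4 (1.19 log units; beyond the scatter), and the direction seen on the core of compound 1 recurs: the same change on two cores in this assay, an at least 10-fold higher number (1.00 log units; beyond the scatter) from compound 1 to compound 3 and an at least 15-fold higher number (1.19 log units; beyond the scatter) from compound 2 to compound 4; the limit leaves it open whether they differ

Compound 4 reaches only a limit of the assay, > 100000 nM. The two cores shown therefore agree in the direction of the methoxy change, but this pair does not show that the change has the same size on both, and the chloro step between the two compounds at the limit cannot be read.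

The compounds shown leave open what a group other than methoxy would do in the same place, for example a hydroxyl, an amine or a carboxylic acid. They also leave open whether chloro has any effect on the methoxy core, which would take a compound on that core with a value inside the range of this assay.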